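Swapping a Methylthiazole for a Phenylisoxazole on the Amide

The source may report more compounds than this note shows. Statements on the series, on what has been measured and on what is new or still open speak of the compounds shown alone.

Measured so far:
Compound 1, `Cc1ccc2[nH]c(C(=O)N[C@H]3CN(S(=O)(=O)c4cccnc4)C[C@@H]3C(=O)NCCN(C)C)cc2c1`, gives 8 uL/min in an ADME assay on cells (Hepatocyte, Rattus norvegicus) for metabolic stability; a lower number here means slower removal, a higher number faster removal of the compound.
Compound 2, `Cc1ccc2[nH]c(C(=O)N[C@H]3CCN(C(=O)c4cccnc4)C[C@@H]3C(=O)NCCN(C)C)cc2c1`, gives 6 uL/min in this assay.
Compound 3, `Cc1csc(C(=O)N[C@H]2CN(S(=O)(=O)c3ccccc3)C[C@@H]2C(=O)N[C@H]2CCCNC2)n1`, gives < 1 uL/min in this assay, and this is a limit of the measurement rather than a number.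

Compound 3 thus stands at the floor of what this assay can resolve: the limit of < 1 uL/min in this assay, at which 1 of the 3 values shown sits. Its true rate of removal is known only to lie somewhere under that floor, while compound 1 and compound 2 each returned a measurable number.

The unmeasured compound 4, `O=C(N[C@H]1CN(S(=O)(=O)c2ccccc2)C[C@@H]1C(=O)N[C@H]1CCCNC1)c1cc(-c2ccccc2)on1`, differs from compound 3 in a single place: 5-phenyl-1,2-oxazol-3-yl in place of 4-methyl-1,3-thiazol-2-yl on a carbonyl carbon. The shared core and both amide arms stay the same. Within the data shown here, no measured pair in this set isolates a swap of this kind, so there is no step to lean on, and the change itself offers no measured property to point to.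

Since compound 3 sits at the limit, even a modest rise would still leave compound 4 close to it. I expect the step from compound 3 to compound 4 in this assay to be an at least 2.0-fold higher number from compound 3 to compound 4 (0.30 log units; that floor lies within the scatter), an upward move of small size that may well fall within the scatter. For compound 4 I estimate 2 uL/min in this assay, with a range from 0.7 uL/min to 6 uL/min.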

Compound 4, intrinsic clearance in a liver preparation (reported as CLH), per the amount of preparation that the assay uses: 6.8 uL/min
For compound 4 the middle estimate is 3.4-fold (0.53 log units) below the measured one; the measured number lies above the stated range.
By their numbers in this assay, from the lowest: compounds 2, 4 and 1 (each within the scatter of the next). At a limit, below all of these: compound 3.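

In this assay, the group on the carbonyl carbon proves able to change how fast the compound is removed: 5-phenyl-1,2-oxazol-3-yl in place of 4-methyl-1,3-thiazol-2-yl brings an at least 6.8-fold higher number from compound 3 to compound 4 (0.83 log units; beyond the scatter). Among these compounds, the earlier compounds offered no pair differing in one place, so this is the first step that ties a change in removal to a single change, here with the shared core and both amide arms held fixed. The printed size is only a lower bound on the real step because the value for compound 3 is a limit of the measurement: the limit of < 1 uL/min in this assay, at which 1 of the 4 values shown sits.

The compounds shown leave open whether the step comes from the added phenyl ring or from the exchange of one five-membered aromatic ring for the other, as both changes arrive together in compound 4. A 5-methyl-1,2-oxazol-3-yl group on the same carbonyl carbon would help separate the two, as it keeps the new five-membered ring and carries a methyl group where compound 4 has its phenyl ring.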